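This account rests on a few compounds, and the source may have more. Where it says the series, first, only, none or still open, it means among the compounds named here.

Compound 1 `COc1nc(C)c(Nc2nc(Cl)cn([C@H](COC(C)=O)C3CC3)c2=O)cc1C`: 5.3 nM; compound 2 `COc1nc(C)c(Nc2nc(Cl)cn([C@H](COC(=O)c3cccnc3)C3CC3)c2=O)cc1C`: 5.2 nM; compound 3 `COc1nc(C)c(Nc2nc(Cl)cn([C@H](COC(=O)Nc3ccc(Cl)cc3)C3CC3)c2=O)cc1C`: 1.6 nM, all in an assay on frontal cortex for displacement of a labelled ligand from corticotropin-releasing factor receptor 1 (Rattus norvegicus), with a stated time of 2 h; on this read-out higher numbers stand for weaker inhibition and lower numbers for stronger inhibition.

Compound 3 gives the lowest number of the three, and both steps leading to it, a 3.3-fold lower number from compound 1 to compound 3 (0.52 log units; beyond the scatter) and a 3.3-fold lower number from compound 2 to compound 3 (0.51 log units; beyond the scatter), lie beyond the scatter. Compound 4 `CCCCNC(=O)OC[C@H](C1CC1)n1cc(Cl)nc(Nc2cc(C)c(OC)nc2C)c1=O` differs from compound 3 by butyl in place of 4-chlorophenyl on an amide-type nitrogen; the group that leaves is the one that entered in the steps to compound 3. Among the measured compounds shown here, no measured compound carries a butyl at that place, so those steps bear only indirectly, while a 1.0-fold lower number from compound 1 to compound 2 (0.01 log units; within the scatter) shows that a swap there can also leave the number unchanged. In this assay a modest rise in the number is expected, a 2.5-fold higher number from compound 3 to compound 4 (0.40 log units; beyond the scatter). Compound 4 is estimated at 4 nM, between 1.5 nM and 10 nM.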

Compound 4, half-maximal inhibitory concentration: 4.7 nM
The estimate for compound 4 lay 1.2-fold (0.07 log units) below the measured number; low and high end bracket the measured number.
By their numbers in this assay, from the lowest: compound 3; then compounds 4, 2 and 1 (each within the scatter of the next).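

In this assay, the aromatic ring on the amide-type nitrogen proves better than an open chain of carbon: butyl in place of 4-chlorophenyl gives a modest loss (a 2.9-fold higher number from compound 3 to compound 4 (0.47 log units; beyond the scatter)). The amide-type nitrogen alone therefore does not bring the lower number, since compound 4 stays level with both esters (a 1.1-fold lower number from compound 2 to compound 4 (0.04 log units; within the scatter); a 1.1-fold lower number from compound 1 to compound 4 (0.05 log units; within the scatter)). From the compounds shown here alone, whether a plain phenyl without the chlorine would hold the lower number of compound 3, or a longer chain such as hexyl would recover it, stays open. Nothing measured here explains the gap between butyl and 4-chlorophenyl.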